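Azido nucleoside series: antiproliferative readout, loss of ring methyl

The source may hold more compounds than are shown below. What is called first, only, known or untested is meant among the compounds shown, and "the series" means these compounds.

Measured compounds:
Compound 1 `C[C@@]1(O)[C@H](n2ccc(N)nc2=O)O[C@@](CO)(N=[N+]=[N-])[C@H]1O` — in a functional assay on 2209-23 cells (Homo sapiens) for antiproliferative activity, read by scintillation proximity assay and thymidine incorporation (a higher number here means a weaker inhibitor, a lower number a stronger inhibitor), compound 1 has "not determined" (no result reported).
Compound 2 `[N-]=[N+]=N[C@]1(CO)O[C@@H](n2ccc(N)nc2=O)[C@@H](O)[C@@H]1O` — in this assay compound 2 reaches only < 100000 nM, which is a limit of the assay and not a number.

Where compound 1 stands: no single number exists for it in this assay, so it cannot be placed against anything. Among the compounds with values here, the one further value, that of compound 2, is a limit, as noted in the limit of < 100000 nM in this assay, at which 1 of the 2 values shown sits. Within the data shown here, no step between measured compounds can be drawn here.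

Compound 3 `[N-]=[N+]=N[C@]1(CO)O[C@@H](n2ccc(N)nc2=O)[C@H](O)[C@@H]1O` is not yet measured. It differs from compound 1 by hydrogen in place of methyl on a saturated ring carbon. Among the measured compounds shown here, with no measured step to lean on, the expectation for this change is a step of no more than modest size, in either direction, and quite possibly none beyond the usual scatter. Compound 3 is expected to give 20000 nM in this assay, with a range of 2000 nM to 100000 nM, and a limit-only result is a real possibility.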

Compound 3, half-maximal inhibitory concentration: < 100000 nM
Compound 3 gave a limit, no number (the forecaster's own chance of this, stated with the estimate: 50%); the middle value is on the limit's open side.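

No step can be read from compound 2 to compound 3, nor from compound 1 to compound 3, in this assay: the limit of < 100000 nM in this assay, at which 2 of the 3 values shown sit.

Going by these compounds, it remains open whether hydrogen in place of methyl, or the stereocentre drawn S in compound 2 and R in compound 3, changes antiproliferative activity at all.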